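The source may hold more compounds than are shown below. What is called first, only, known or untested is meant among the compounds shown, and "the series" means these compounds.

Measured so far:
compound 1, `CC(Sc1nc2nn(C3(C)COC3)cc2c(=O)n1-c1ccccc1)c1ccccc1`: 50 nM
compound 2, `CC(Sc1nc2c(cnn2C)c(=O)n1-c1ccccc1)c1cccc(F)c1`: 128 nM
compound 3, `Cn1ncc2c(=O)n(-c3ccccc3)c(CNc3cccc(F)c3)nc21`: 1050 nM

These three numbers come from an assay on isolated protein for inhibition of Retinaldehyde dehydrogenase 3 (Homo sapiens); a lower number here means a stronger inhibitor, a higher number a weaker inhibitor. Among them compound 2 sits second highest: compound 1 lies nearest with a lower number, beyond the scatter, and compound 3 lies furthest with a higher number, also beyond the scatter. Compound 4, `CC(Sc1nc2c(cnn2C)c(=O)n1-c1ccccc1)c1ccccc1`, is the next compound to be measured in this assay. It differs from compound 2 in one place: hydrogen in place of fluoro on an aromatic carbon. Put another way, the 1-(3-fluorophenyl)ethyl group of compound 2 becomes a 1-phenylethyl group. Among the measured compounds shown here, no pair of measured compounds differs in just this way, so the data give no step for a change of this kind. A small shift is expected, if any, with the step of a 1.2-fold lower number from compound 2 to compound 4 (0.07 log units; within the scatter) unlikely to reach beyond the usual scatter. Compound 4 is therefore estimated at 110 nM, within a range from 50 nM to 250 nM.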

Compound 4, half-maximal inhibitory concentration: 73 nM
Beside the measured number, compound 4's estimate is 1.5-fold (0.18 log units) above it; measured number inside the range.
By their numbers in this assay, from the lowest: compounds 1, 4 and 2 (each within the scatter of the next, the first and the last beyond it); then compound 3.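

With hydrogen in place of fluoro on this aromatic carbon, this assay gives a 1.8-fold lower number from compound 2 to compound 4 (0.24 log units; within the scatter), the first step measured at this position. The fluoro is therefore not needed here: compound 2 and compound 4 cannot be told apart in this assay. No supporting measurement bears on this result.

Still open, on these data alone, is how larger or different groups on this carbon, such as a chlorine, a methoxy or an amine, would read. This single pair also cannot say whether the same exchange would read alike on the other compounds' cores.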